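Sulfonamide swap on the shared core: compound 4 expected

A few compounds are considered here, and "the series" means these few. Any claim that something is new, unique, unknown or untested is made for them only; others in the source may bear on it.

Measured so far:
- Compound 1, `CCN(CC)S(=O)(=O)c1ccc(S(=O)(=O)N2CCC[C@@H](C(=O)N3CCC(F)(F)CC3)C2)cc1`, 120 nM
- Compound 2, `O=C([C@@H]1CCCN(S(=O)(=O)c2ccc(S(=O)(=O)C3CCC3)cc2)C1)N1CCC(F)(F)CC1`, 78 nM
- Compound 3, `CCN(CC)S(=O)(=O)c1ccc(S(=O)(=O)N2CCC[C@@H](C(=O)N3CCS(=O)(=O)CC3)C2)cc1`, 4430 nM

In a functional assay on BXPC-3 cells (Homo sapiens) for inhibition, read by MTT assay, with a stated time of 7 days (on this read-out higher numbers stand for weaker inhibition and lower numbers for stronger inhibition), compound 1 stands second highest of the three numbers. Its nearest neighbour is compound 2, a step of a 1.5-fold lower number from compound 1 to compound 2 (0.19 log units; within the scatter), which came from exchanging a group on the sulfonyl sulfur. Its furthest neighbour is compound 3, a step of a 37-fold higher number from compound 1 to compound 3 (1.57 log units; beyond the scatter), which came from a change on the carbonyl carbon instead.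

Compound 4, `O=C([C@@H]1CCCN(S(=O)(=O)c2ccc(S(=O)(=O)N3CC[C@@H](O)C3)cc2)C1)N1CCC(F)(F)CC1`, differs from compound 1 by 3-hydroxypyrrolidin-1-yl in place of diethylamino on a sulfonyl sulfur. This change sits at the same sulfonyl sulfur as the change from compound 1 to compound 2, so that step is the one that bears on it, and it stayed within the scatter. The change at the carbonyl carbon, which gave the large step to compound 3, is not involved here. The expected step is therefore a 1.3-fold higher number from compound 1 to compound 4 (0.10 log units; within the scatter), nothing beyond the scatter. For compound 4 the estimate in this assay is 150 nM, with a range from 60 nM to 400 nM.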

Compound 4, half-maximal inhibitory concentration: 330 nM
Beside the measured number, compound 4's estimate is 2.2-fold (0.34 log units) below it, within the range that was stated.
By their numbers in this assay, from the lowest: compounds 2 and 1 (each within the scatter of the next); then compound 4; then compound 3.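

In this assay, the sulfonyl sulfur turns out not to be indifferent to the group it carries: 3-hydroxypyrrolidin-1-yl in place of diethylamino gives a 2.8-fold higher number from compound 1 to compound 4 (0.44 log units; beyond the scatter), whereas the earlier exchange for cyclobutyl stayed within the scatter. Measured against cyclobutyl, the same group gives a 4.2-fold higher number from compound 2 to compound 4 (0.63 log units; beyond the scatter), so of the three groups compared at this place, 3-hydroxypyrrolidin-1-yl carries the highest number. No available evidence accounts for this loss of inhibition.

The compounds shown do not separate the effect of the hydroxyl from that of the ring, a question that plain pyrrolidin-1-yl on the same sulfur would address, and the opposite stereocentre of 3-hydroxypyrrolidin-1-yl also remains open. From the compounds shown here alone, it is equally open whether the step would hold with 1,1-dioxothiomorpholin-4-yl on the carbonyl carbon.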